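This account rests on a few compounds, and the source may have more. Where it says the series, first, only, none or still open, it means among the compounds named here.

Measured so far in a functional assay on MDA-MB-231 cells (Homo sapiens) for cytotoxicity, read by MTT assay, with a stated time of 72 h; a higher number here means a weaker inhibitor, a lower number a stronger inhibitor:
- compound 1 `O=C1CS/C(=N\c2csc(-c3ccccc3)c2)N1`: > 50000 nM
- compound 2 `Cc1ccc(/C=C2\S/C(=N\c3csc(-c4ccc(Cl)cc4)c3)NC2=O)cc1`: 900 nM
- compound 3 `COc1cccc(N2C(=O)CS/C2=N\c2csc(-c3ccccc3)c2)c1`: "not determined" (no result reported)

Compound 1 has the entry > 50000 nM, which is a limit of the assay and not a number. Compound 2, at 900 nM, is the only one of the three with an actual number. Compound 3 has no result: in this assay compound 3 has the entry "not determined" (no result reported), so there is no figure to start from.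

The next structure is compound 4 `COc1ccc(-c2cc(/N=C3\SCC(=O)N3c3cccc(OC)c3)cs2)cc1`. The change is methoxy in place of hydrogen on an aromatic carbon, which turns phenyl to 4-methoxyphenyl. Among the measured compounds shown here, no pair of measured compounds shows what this change does. The expectation in this assay is therefore a small step of open direction, possibly none beyond the usual scatter. The expectation for compound 4 still leans towards weak inhibition because without the extra group carried by compound 2 compound 1 reached only the limit > 50000 nM. Compound 4 is estimated at 25000 nM, with an expected range from 5000 nM to 100000 nM.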

Compound 4, half-maximal inhibitory concentration: 2700 nM
Compound 4: middle estimate off by 9.3-fold (0.97 log units), on the high side; the whole stated range lies above it.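

Among the compounds shown here, compound 3 has no result in this assay, so the change from it to compound 4, which gives 2700 nM there, offers no step that can be read. The compounds shown leave open what turning phenyl to 4-methoxyphenyl does to the activity. Nothing shown accounts for the value of compound 4.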